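Adding a methyl to the ring amine: expected efficacy

A few compounds are considered here, and "the series" means these few. Any claim that something is new, unique, unknown or untested is made for them only; others in the source may bear on it.

In a functional assay on synaptosomes from brain (strain Sprague-Dawley) for agonist activity at Nicotinic acetylcholine receptor alpha6/alpha3/beta2/beta3 (Rattus norvegicus) (on this read-out lower numbers stand for smaller maximal responses and higher numbers for larger maximal responses), three compounds have been measured. Compound 2 `C1=C(c2cccnc2)C[C@H]2CNC[C@@H]1C2` gives 73%, and compound 1 `CN1C[C@H]2C=C(c3cccnc3)C[C@H](C2)C1` gives 27%. The two differ only by methyl in place of hydrogen on an amine nitrogen in a ring; that change made a number 46 percentage points lower from compound 2 to compound 1 (beyond the scatter). Compound 3 `CC(C)Oc1cncc(C2=CC3CNCC(C2)C3)c1` gives 86%, the highest of the three. The difference between the core of compound 3 and that of compound 2 is not broken down here. Compound 4 `CC(C)Oc1cncc(C2=CC3CC(C2)CN(C)C3)c1` has not yet been measured; it differs from compound 3 by methyl in place of hydrogen on an amine nitrogen in a ring, the same change as from compound 2 to compound 1. Among the measured compounds shown here, the only guide is the earlier step, a number 46 percentage points lower from compound 2 to compound 1 (beyond the scatter). On that basis a step of about the same size is expected, a number 46 percentage points lower from compound 3 to compound 4 (beyond the scatter). Compound 4 is therefore estimated to give 40%, likely between 20% and 60%.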

Compound 4, largest response reached (reported as percent of maximum), in percent of the reference or control that the assay uses: 63%
Beside the measured number, compound 4's estimate is 23 percentage points below it, outside the stated range (above it).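

In this assay, methyl in place of hydrogen on an amine nitrogen in a ring lowers the response on both cores, but the size of the drop does not carry over unchanged, with a number 23 percentage points lower from compound 3 to compound 4 (beyond the scatter) being smaller than the earlier step: the same change on two cores in this assay, a number 46 percentage points lower (beyond the scatter) from compound 2 to compound 1 and a number 23 percentage points lower (beyond the scatter) from compound 3 to compound 4, 23 percentage points apart, beyond the scatter of two such steps The direction of the change therefore held in these two pairs, while its size differed from one core to the other. Two pairs do not show why the size differs, or what the same change would do on a further core.

Going by these compounds, whether an ethyl or a longer chain on that nitrogen would lower the response further remains open. So does whether either core would respond to such a group in the same way.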